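The source may hold more compounds than are shown below. What is called first, only, known or untested is meant among the compounds shown, and "the series" means these compounds.

Compound 1 `c1ccc2c(-c3cn4ccnc4c(-c4ccc5ncn(C6CCCCC6)c5c4)n3)cccc2c1` was tested in a functional assay on UACC-62 cells (Homo sapiens) for inhibition, read by sulforhodamine B assay, with a stated time of 48 h, tested at 10 uM (on this read-out lower numbers stand for less inhibition and higher numbers for more inhibition at the one concentration tested (going by the name of the read-out)), and gives 16.7%. Compound 2 `c1cn2cc(-c3ccsc3)nc(-c3ccc4ncn(C5CCCCC5)c4c3)c2n1`, which carries thiophen-3-yl in place of naphthalen-1-yl on an aromatic carbon, gives in this assay a reading of 18.4%. The single step between the two measured compounds, a number 1.7 percentage points higher from compound 1 to compound 2 (within the scatter), lies within the scatter of repeated measurements, so on the two numbers shown compound 2 sits alongside compound 1 rather than apart from it.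

The next compound, compound 3 `Brc1ccc(-c2cn3ccnc3c(-c3ccc4ncn(C5CCCCC5)c4c3)n2)cc1`, is not yet measured in this assay. Its difference from compound 2 is 4-bromophenyl in place of thiophen-3-yl on an aromatic carbon. Within the data shown here, the only measured step that bears on this change is the exchange of one aryl group for another at the same place, a number 1.7 percentage points higher from compound 1 to compound 2 (within the scatter), and that step stayed within the scatter. On that basis no step beyond the scatter is expected in this assay for compound 3 in either direction, though the evidence rests on one pair alone.

Compound 3 is therefore estimated at 18%, with a range from 5% to 32%. This estimate means an expected step of a number 0.4 percentage points lower from compound 2 to compound 3 (within the scatter).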

Compound 3, a percentage reported as inhibition, at one concentration (the size of the read-out at that concentration, not a potency): 46.9%
For compound 3 the middle estimate is 28.9 percentage points below the measured one, outside the stated range (above it).
By their numbers in this assay, from the lowest: compounds 1 and 2 (each within the scatter of the next); then compound 3.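

In this assay, the aryl group on this aromatic carbon, next to the ring nitrogen, proves not to be freely exchangeable: placing 4-bromophenyl there in lieu of thiophen-3-yl gives a number 28.5 percentage points higher from compound 2 to compound 3 (beyond the scatter), and placing it there in lieu of naphthalen-1-yl gives a number 30.2 percentage points higher from compound 1 to compound 3 (beyond the scatter). The two earlier aryl groups had given readings within the scatter of each other and so suggested a position indifferent to the group it carries, whereas 4-bromophenyl now stands clear of both and shows that the read-out can respond to a change at this place. No measurement is available that would explain why this one group stands apart.

The compounds shown leave open whether the higher reading goes with the bromine or with the six-membered carbon ring itself, a question that an unsubstituted phenyl, a 4-chlorophenyl or a 4-methoxyphenyl at the same place would address. Going by these compounds, they also leave open how a group of another kind would read there, such as an amine or a phenyl ring bearing a carboxylic acid, and all of these readings come from one concentration only, so the potency of compound 3 remains unknown.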